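The source may report more compounds than this note shows. Statements on the series, on what has been measured and on what is new or still open speak of the compounds shown alone.

Measured compounds:
compound 1 `O=C(NC[C@]1(CC2CC2)[C@@H]2CN(S(=O)(=O)CC3CC3)C[C@@H]21)c1ccc(Cl)cc1Cl` — 230 nM
compound 2 `Cn1cnc(S(=O)(=O)N2C[C@@H]3[C@H](C2)[C@@]3(CNC(=O)c2ccc(Cl)cc2)CC2CC2)c1` — 32 nM
compound 3 `Cn1cnc(S(=O)(=O)N2C[C@@H]3[C@H](C2)[C@@]3(CNC(=O)c2cc(Cl)cc(Cl)c2)CC2CC2)c1` — 100 nM

In an assay on isolated protein for inhibition of sodium- and chloride-dependent glycine transporter 1 (Homo sapiens) (on this read-out higher numbers stand for weaker inhibition and lower numbers for stronger inhibition), compound 1 gives 230 nM, the highest of the three numbers; compound 3 sits nearer to it with 100 nM, and compound 2 furthest with 32 nM. Within the data shown here, the one step within the measured set, a 3.1-fold higher number from compound 2 to compound 3 (0.49 log units; beyond the scatter), concerns the carbonyl carbon and not the sulfonyl sulfur, so it does not bear on the change at hand. Among the measured compounds shown here, compounds 2 and 3 differ from compound 1 in more than one place, so their values give no single step for the sulfonyl position either.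

Compound 4 `O=C(NC[C@]1(CC2CC2)[C@@H]2CN(S(=O)(=O)c3cccnc3)C[C@@H]21)c1ccc(Cl)cc1Cl` differs from compound 1 by pyridin-3-yl in place of cyclopropylmethyl on a sulfonyl sulfur. For the measured compounds named here, no measured step covers this exchange, so no direction beyond the scatter can be read from the data; the step is expected to stay within the usual scatter, with a wide range allowed. The expected step is a 1.3-fold lower number from compound 1 to compound 4 (0.11 log units; within the scatter). Compound 4 is expected to give about 180 nM in this assay, between 50 nM and 600 nM.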

Compound 4, half-maximal inhibitory concentration: 890 nM
Estimate against measurement, compound 4: 4.9-fold (0.69 log units) below; the whole stated range lies below it.
By their numbers in this assay, from the lowest: compound 2; then compound 3; then compound 1; then compound 4.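

In this assay, among these compounds, this is the first single-place reading at the sulfonyl sulfur: exchanging cyclopropylmethyl for pyridin-3-yl gives a 3.9-fold higher number from compound 1 to compound 4 (0.59 log units; beyond the scatter), a modest step towards weaker inhibition. The position is therefore not indifferent to the group it carries, and with the rest of compound 1 held fixed, this aromatic ring bearing one nitrogen is the less favourable of the two groups compared. Nothing at hand explains the step.

Among the compounds shown here, the single exchange cannot separate the effect of the ring nitrogen from that of replacing a cyclopropylmethyl group with an aromatic ring, so it remains open where a plain phenyl or a pyridin-2-yl group would fall. Also open, as far as these compounds go, is whether a simple methyl or a longer alkyl chain on the sulfonyl sulfur would stay close to compound 1.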